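This account rests on a few compounds, and the source may have more. Where it says the series, first, only, none or still open, it means among the compounds named here.

Working notes on the sulfonamide series, all on the shared core of compound 1 `O=S(=O)(Nc1ccc2oc(-c3ccccc3)nc2c1)c1ccccc1Cl`. In an ADME assay on HEK293 cells (Homo sapiens) for cytotoxicity, read by resazurin assay, with a stated time of 48 h (a higher number here means that more compound is tolerated, a lower number that less compound is tolerated), compound 1 gives 73000 nM and compound 2 `COc1ccc(Cl)cc1S(=O)(=O)Nc1ccc2oc(-c3ccccc3)nc2c1` gives 74000 nM. Compound 3 `O=S(=O)(Nc1ccc2oc(-c3ccccc3)nc2c1)c1ccc(O)cc1` gives > 100000 nM, which is a limit of the assay and not a number.

Next is compound 4 `O=S(=O)(Nc1ccc2oc(-c3ccccc3)nc2c1)c1ccccc1O`, which has 2-hydroxyphenyl in place of 4-hydroxyphenyl on a sulfonyl sulfur. The two have the same atoms, joined differently, and this exact change has not been measured in the series.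

The nearest evidence comes from other replacements at the same place. These are a 1.0-fold higher number from compound 1 to compound 2 (0.01 log units; within the scatter), an at least 1.3-fold higher number from compound 1 to compound 3 (0.13 log units; that floor lies within the scatter) and an at least 1.3-fold higher number from compound 2 to compound 3 (0.13 log units; that floor lies within the scatter). Given those three steps, none of which is shown beyond the scatter, no clear shift is expected in this assay. The expected change is an at least 1.1-fold lower number from compound 3 to compound 4 (0.04 log units; that floor lies within the scatter), with no direction expected beyond the scatter. For compound 4, the estimated value is 90000 nM, with an expected range of 50000 nM to 100000 nM.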

Compound 4, half-maximal cytotoxic concentration: 33000 nM
Compound 4: middle estimate off by 2.7-fold (0.44 log units), on the high side, and the stated range ends above it.
By their numbers in this assay, from the lowest: compound 4; then compounds 1 and 2 (each within the scatter of the next). At a limit, above all of these: compound 3.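

In this assay this position now shows a change beyond the scatter: 2-hydroxyphenyl in place of 4-hydroxyphenyl on the sulfonyl sulfur gives an at least 3.0-fold lower number from compound 3 to compound 4 (0.48 log units; beyond the scatter) with the same atoms, joined differently, whereas no earlier step was shown beyond the scatter. Compound 4 also falls apart from the chloro-bearing compounds, with a 2.2-fold lower number from compound 2 to compound 4 (0.35 log units; beyond the scatter) and with a 2.2-fold lower number from compound 1 to compound 4 (0.34 log units; beyond the scatter), so hydroxy on the ring does not by itself go with more compound tolerated. The step from compound 3 is only a floor, since compound 3 stands at a limit of the assay: the limit of > 100000 nM in this assay, at which 1 of the 4 values shown sits.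

Going by these compounds, whether an amine or a carboxylic acid on this aromatic ring would follow 2-hydroxyphenyl or 4-hydroxyphenyl stays open. What lies behind the lower number of compound 4 also stays open.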